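Ester Variation on a Sesquiterpene Lactone Core

The source may report more compounds than this note shows. Statements on the series, on what has been measured and on what is new or still open speak of the compounds shown alone.

Measured compounds:
- compound 1, `C=C1C(=O)O[C@H]2CC3=C[C@H](C/C(C)=C/[C@@H](OC(=O)c4ccc(C(C)=O)cc4)[C@H]12)OC3=O`: 2200 nM
- compound 2, `C=C1C(=O)O[C@H]2CC3=C[C@H](C/C(C)=C/[C@@H](OC(=O)c4ccc(-c5ccccc5)cc4)[C@H]12)OC3=O`: 3500 nM
- compound 3, `C=C1C(=O)O[C@H]2CC3=C[C@H](C/C(C)=C/[C@@H](OC(=O)/C=C/c4ccc(N(C)C)cc4)[C@H]12)OC3=O`: 1300 nM

Three esters of the shared core have been tested in a functional assay on NCI-H460 cells (Homo sapiens) for cytotoxicity, read by MTT assay, with a stated time of 48 h; on this read-out higher numbers stand for weaker inhibition and lower numbers for stronger inhibition. Compound 3 gives the lowest number of the three; it sits within the scatter of compound 1 and beyond the scatter of compound 2. The two steps seen so far both alter the ester group: a 1.6-fold higher number from compound 1 to compound 2 (0.20 log units; within the scatter) and a 1.7-fold lower number from compound 1 to compound 3 (0.23 log units; within the scatter). Neither reaches beyond the scatter, so the ester group has tolerated change without a clear shift in this assay.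

Compound 4, `C=C1C(=O)O[C@H]2CC3=C[C@H](C/C(C)=C/[C@@H](OC(=O)C(C)(C)CC)[C@H]12)OC3=O`, continues this series with a different kind of ester. The change from compound 3 is 1,1-dimethylpropyl in place of 2-(4-(dimethylamino)phenyl)ethenyl on a carbonyl carbon. Going by the values given here, no measured step exchanges an aromatic ester for a branched alkyl one, so neither step bears on it directly; the only guide is that ester changes so far have stayed within the scatter.

The expectation is therefore a modest step, a 1.9-fold higher number from compound 3 to compound 4 (0.28 log units; within the scatter), with compound 4 estimated at 2500 nM in this assay, within a range from 900 nM to 7000 nM.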

Compound 4, half-maximal inhibitory concentration: 6100 nM
The estimate for compound 4 lay 2.4-fold (0.39 log units) below the measured number, within the range that was stated.
By their numbers in this assay, from the lowest: compounds 3, 1, 2 and 4 (each within the scatter of the next, the first and the last beyond it).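

On the carbonyl carbon of the ester, this assay now shows changes that go beyond the scatter: 1,1-dimethylpropyl in place of 2-(4-(dimethylamino)phenyl)ethenyl gives a 4.7-fold higher number from compound 3 to compound 4 (0.67 log units; beyond the scatter) and 1,1-dimethylpropyl in place of 4-acetylphenyl gives a 2.8-fold higher number from compound 1 to compound 4 (0.44 log units; beyond the scatter). The position therefore does not tolerate every ester equally, and in both steps a group with a six-membered aromatic ring gives way to one with no ring, although compound 2, whose ester also holds aromatic rings, goes against any simple reading in terms of the ring, as it stands within the scatter of compound 4. Nothing available here accounts for the shift, so it remains a description of the numbers alone.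

Going by these compounds, it remains open whether the loss follows from the branching of 1,1-dimethylpropyl or from the absence of a ring, which a straight pentyl chain or a cyclohexyl ester would help to separate. Also open, on these data alone, is how an ester bearing an amine or a carboxylic acid on a simple alkyl chain would stand against these four compounds on the shared core.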